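This account rests on a few compounds, and the source may have more. Where it says the series, first, only, none or still open, it means among the compounds named here.

Measured compounds in a functional assay on HBL-100 cells (Homo sapiens) for inhibition, read by sulforhodamine B assay, with a stated time of 48 h; a lower number here means a stronger inhibitor of growth, a higher number a weaker inhibitor of growth:

compound 1 `COC(=O)[C@@]1(C)CCC=C2[C@@H]1CC[C@@H](C)[C@]2(C)Cc1c[nH]c2ccc(C(F)(F)F)cc12`: 15000 nM
compound 2 `COC(=O)[C@@]1(C)CCC=C2[C@@H]1CC[C@@H](C)[C@]2(C)Cc1c(C)[nH]c2ccc(C(F)(F)F)cc12`: 16000 nM
compound 3 `COC(=O)[C@@]1(C)CC[C@@H]2C3=C1CC[C@@H](C)[C@]3(C)C[C@@H]1c3ccccc3N[C@H]21`: 78000 nM

Compound 1 and compound 2 share one core and differ by methyl in place of hydrogen on an aromatic carbon; the step is a 1.1-fold higher number from compound 1 to compound 2 (0.03 log units; within the scatter). Compound 3 has a different core; how its core differs from that of compound 1 is not broken down here. In this assay compound 3 gives the highest number of the three, and its gap to compound 1 and to compound 2 lies beyond the usual scatter.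

Compound 4 `COC(=O)[C@@]1(C)CC[C@@H]2C3=C1CC[C@@H](C)[C@]3(C)C[C@@H]1c3cccc(C)c3N[C@H]21` is not yet measured. It differs from compound 3 by methyl in place of hydrogen on an aromatic carbon. This is the same kind of change as from compound 1 to compound 2, not the same: there the methyl enters on a five-membered aromatic ring with one nitrogen, part of a fused system of two rings, next to the ring nitrogen and next to the ring atom that bears a large group; here it enters on a six-membered aromatic ring of carbon only, part of a fused system of five rings, ortho to a fused ring and meta to a fused ring.

Within the data shown here, the only precedent is the step of a 1.1-fold higher number from compound 1 to compound 2 (0.03 log units; within the scatter), which lies within the scatter, so the step from compound 3 to compound 4 is expected to be small, about a 1.0-fold higher number from compound 3 to compound 4 (0.01 log units; within the scatter), though the different ring and core leave this uncertain. Compound 4 is expected to give about 80000 nM in this assay, between 35000 nM and 180000 nM.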

Compound 4, concentration for 50% growth inhibition: 32000 nM
Estimate against measurement, compound 4: 2.5-fold (0.40 log units) above; measured number below the stated range.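

In this assay, methyl in place of hydrogen on an aromatic carbon of the six-membered aromatic ring of carbon only gives a 2.4-fold lower number from compound 3 to compound 4 (0.39 log units; beyond the scatter), a modest step. Among these compounds, this does not establish that the core decides the size of the step, and with only one pair on each core it does not establish that the change carries over unchanged either, since the methyl also enters a different kind of ring in each pair. Set side by side, the two steps cannot be told apart, even though only the newer one lies beyond the scatter on its own: the same change on two cores in this assay, a 1.1-fold higher number (0.03 log units; within the scatter) from compound 1 to compound 2 and a 2.4-fold lower number (0.39 log units; beyond the scatter) from compound 3 to compound 4, 2.6-fold (0.41 log units) apart, within the scatter of two such steps.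

The compounds shown leave open whether a longer chain such as ethyl, or a methoxy group, would follow the methyl at this place on the core of compound 3, and whether methyl on the other carbons of that ring would give a similar step. They also leave open what a carboxylic acid in place of the methyl ester would do on either core.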